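The source may report more compounds than this note shows. Statements on the series, on what has been measured and on what is new or still open speak of the compounds shown alone.

Measured compounds:
- compound 1, `O=C1/C(=C/c2ccccc2)CCC/C1=C\c1ccc(Cl)cc1`: 27.6%
- compound 2, `O=C1/C(=C/c2ccccc2)CCC/C1=C\c1ccc(Br)cc1`: 29.1%

In an assay on isolated protein for inhibition of Alpha glucosidase (Homo sapiens), with stated times of 5 min and 15 min, tested at 50 uM (on this read-out lower numbers stand for less inhibition and higher numbers for more inhibition at the one concentration tested (going by the name of the read-out)), compound 1 gives 27.6%, the lowest of the two numbers in hand; its nearest neighbour is compound 2, which gives 29.1%, and the step of a number 1.5 percentage points higher from compound 1 to compound 2 (within the scatter) lies within the scatter, so the two compounds cannot be told apart on this read-out.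

Compound 3, `O=C1/C(=C/c2ccccc2)CCC/C1=C\c1ccc(Cl)c(Cl)c1`, has not been measured in this assay. It differs from compound 1 by chloro in place of hydrogen on an aromatic carbon. Going by the values given here, the only measured step, that from compound 1 to compound 2, concerns bromo in place of chloro on an aromatic carbon and was within the scatter; no step with chloro in place of hydrogen has been measured, so the bearing of the known step on this change is indirect. On that basis the step of a number 3.4 percentage points higher from compound 1 to compound 3 (within the scatter) is expected to be small, with no clear direction beyond the scatter. For compound 3 the inhibition in this assay is estimated at 31%, within a range from 18% to 45%.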

Compound 3, a percentage reported as inhibition, at one concentration (the size of the read-out at that concentration, not a potency): 48.4%
Beside the measured number, compound 3's estimate is 17.4 percentage points below it; the whole stated range lies below it.
By their numbers in this assay, from the lowest: compounds 1 and 2 (each within the scatter of the next); then compound 3.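

In this assay, placing a chloro group on an aromatic carbon, ortho to the chloro group of compound 1 and meta to a large group, gives a number 20.8 percentage points higher from compound 1 to compound 3 (beyond the scatter) and so shows that this position can respond to a substitution. Going by these compounds alone, the earlier exchange of bromo for chloro gave only a number 1.5 percentage points higher from compound 1 to compound 2 (within the scatter) and did not show such a response, so compound 3 provides the first change here that stands clear of the scatter, although the size of the step remains modest. Nothing available here accounts for the rise, and its origin remains unknown.

The compounds shown leave open whether the rise is particular to chloro or would also appear with fluoro, methoxy, an amine or a carboxylic acid at this position. They also leave open whether a chloro group here would give a similar step without the chloro group already present in compound 1, or alongside the bromo group of compound 2.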